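Adding a second chloro to a purine-like core

This account rests on a few compounds, and the source may have more. Where it says the series, first, only, none or still open, it means among the compounds named here.

Of the compounds shown here, three have been tested in a functional assay on NCI-H460 cells (Homo sapiens) for cytotoxicity, read by sulforhodamine B assay, with a stated time of 48 h; a lower number here means a stronger inhibitor of growth, a higher number a weaker inhibitor of growth. Compound 1 `ClCc1ccccc1Cn1cnc2c(Cl)nc(Cl)nc21` carries two chloro groups on its shared core and gives 3310 nM. Compound 2 `ClCc1ccccc1Cn1cnc2c(Cl)ncnc21` carries one chloro and gives 15500 nM. Compound 3 `ClCc1ccccc1Cn1cnc2ncnc(Cl)c21` has the same atoms as compound 2, joined differently; in this assay compound 3 gives 13500 nM. The difference between the two cores of compound 2 and compound 3 is not broken down here, and their two values lie within the scatter of each other.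

One step is counted: chloro in place of hydrogen on an aromatic carbon a 4.7-fold lower number from compound 2 to compound 1 (0.67 log units; beyond the scatter). Compound 4 `ClCc1ccccc1Cn1cnc2nc(Cl)nc(Cl)c21` has not yet been measured. It is made from compound 3 by the same kind of change: chloro in place of hydrogen on an aromatic carbon. The place of the incoming chloro is described in the same words in both pairs, so the two changes are alike in their surroundings as far as they are described.

Among the compounds with values here, the expectation for compound 4 rests on that single earlier step, because a 4.7-fold lower number from compound 2 to compound 1 (0.67 log units; beyond the scatter) is the only guide to what the added chloro does on this kind of core. For compound 4 a step of a 4.7-fold lower number from compound 3 to compound 4 (0.67 log units; beyond the scatter) is expected in this assay. Within the data shown here, compound 4 is therefore estimated at 2900 nM, with a range from 1200 nM to 7000 nM, the width reflecting that only one precedent exists and that compound 3 sits on a differently joined core.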

Compound 4, concentration for 50% growth inhibition: 2390 nM
The estimate for compound 4 lay 1.2-fold (0.08 log units) above the measured number, and the stated range covers the measured number.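

In this assay, putting chloro in place of hydrogen on the aromatic carbon between two ring nitrogen atoms gives a 5.6-fold lower number from compound 3 to compound 4 (0.75 log units; beyond the scatter), so the number falls beyond the scatter on this second core as well. Within the data shown here, the same change has now been read on two differently joined cores, and the size of the step carries over from one to the other with no difference that can be told apart: the same change on two cores in this assay, a 4.7-fold lower number (0.67 log units; beyond the scatter) from compound 2 to compound 1 and a 5.6-fold lower number (0.75 log units; beyond the scatter) from compound 3 to compound 4, 1.2-fold (0.08 log units) apart, within the scatter of two such steps This rests on only two pairs of compounds, both read in this assay, so it shows neither why the added chloro lowers the number nor that a step of this size would appear on a further core or in another test.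

All the compounds shown have either chloro or hydrogen on that carbon, which leaves open what an amine, a methoxy group or a longer chain would do there on either core. From the compounds shown here alone, the chloromethyl group outside the shared core also stays the same in all four compounds, so it remains open how the numbers would respond if a hydroxymethyl group or a carboxylic acid stood in its place.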